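Halogen swap on the benzyl arm of the series

The source may hold more compounds than are shown below. What is called first, only, known or untested is meant among the compounds shown, and "the series" means these compounds.

Compound 3 `COc1ccc(C(=O)/C=C/c2ccc(OCc3cn(Cc4ccc(Br)cc4)nn3)cc2)cc1` gives 56% in a functional assay on MIA PaCa-2 cells (Homo sapiens) for inhibition, read by MTT assay, with a stated time of 48 h, tested at 10 uM (on this read-out lower numbers stand for less inhibition of growth and higher numbers for more inhibition of growth at the one concentration tested), and stands second highest of the three numbers: nearest is compound 2 `COc1ccc(C(=O)/C=C/c2ccc(OCc3cn(Cc4cccc(Br)c4)nn3)cc2)cc1` with 50% (within the scatter), furthest is compound 1 `COc1ccc(C(=O)/C=C/c2ccc(OCc3cn(Cc4ccccc4)nn3)cc2)cc1` with 68% (beyond the scatter). Compound 4 `COc1ccc(C(=O)/C=C/c2ccc(OCc3cn(Cc4ccccc4F)nn3)cc2)cc1` differs from compound 3 by 2-fluorophenyl in place of 4-bromophenyl on a saturated chain carbon bound to an aromatic nitrogen. Among the compounds with values here, no measured step covers this swap directly. Within the data shown here, the steps that bear on it are a number 18 percentage points lower from compound 1 to compound 2 (beyond the scatter) and a number 12 percentage points lower from compound 1 to compound 3 (beyond the scatter), both modest losses when bromo replaces hydrogen, and a number 6 percentage points higher from compound 2 to compound 3 (within the scatter), which lies within the scatter. Taking bromo away would be expected to recover part of that loss; for fluorine no comparison exists. For compound 4 a modest rise is therefore expected, a number 4 percentage points higher from compound 3 to compound 4 (within the scatter), to an estimated 60% with a range of 45% to 74%.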

Compound 4, percent growth inhibition at one concentration: 19%
Compound 4: middle estimate off by 41 percentage points, on the high side; the whole stated range lies above it.
By their numbers in this assay, from the lowest: compound 4; then compounds 2 and 3 (each within the scatter of the next); then compound 1.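

Fluoro in place of hydrogen on the benzyl arm brings a large loss in this assay (a number 49 percentage points lower from compound 1 to compound 4 (beyond the scatter)), where bromo brought only modest ones. The 2-fluorophenyl group also falls well short of both bromo groups (a number 31 percentage points lower from compound 2 to compound 4 (beyond the scatter); a number 37 percentage points lower from compound 3 to compound 4 (beyond the scatter)), so compound 4 is the weakest of the four and halogens on this ring are not interchangeable. Nothing available accounts for this drop.

Compound 4 differs from the bromo compounds in both the halogen and its place on the ring, so these two changes stay unseparated. On these data alone, how chloro or an amine on this ring would read also stays open.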